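The source may report more compounds than this note shows. Statements on the series, on what has been measured and on what is new or still open speak of the compounds shown alone.

In a functional assay on DU-145 cells (Homo sapiens) for cytotoxicity, read by MTT assay (a lower number here means a stronger inhibitor, a higher number a weaker inhibitor), compound 1 `CCCC(O)CC(=O)O[C@H](CC=C(C)C)C1=CC(=O)c2c(O)ccc(O)c2C1=O` returns only a limit, > 100000 nM. Going by the values given here, compound 2 `CCC(O)(CC)CC(=O)O[C@H](CC=C(C)C)C1=CC(=O)c2c(O)ccc(O)c2C1=O` gives 67000 nM, the only actual number so far. Among the compounds with values here, the one measured step is an at least 1.4-fold lower number from compound 1 to compound 2 (0.17 log units; that floor lies within the scatter). It swaps one open hydroxylated chain for another, so it offers only a weak guide to the next change. Compound 3 `CC(C)=CC[C@@H](OC(=O)c1ccoc1)C1=CC(=O)c2c(O)ccc(O)c2C1=O` carries furan-3-yl in place of 2-ethyl-2-hydroxybutyl on a carbonyl carbon, which places an aromatic ring where compound 2 has none. A moderately lower number is expected, a 3.4-fold lower number from compound 2 to compound 3 (0.53 log units; beyond the scatter), though this is uncertain. For compound 3 the estimated value is 20000 nM, with an expected range of 3000 nM to 100000 nM.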

Compound 3, half-maximal inhibitory concentration: > 100000 nM
Compound 3: only a limit was reported (the forecaster's own chance of this, stated with the estimate: 10%); at least 5.0-fold (0.69 log units) between middle value and limit.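

With furan-3-yl in place of 2-ethyl-2-hydroxybutyl on the carbonyl carbon, this assay shows an at least 1.4-fold higher number from compound 2 to compound 3 (0.17 log units; that floor lies within the scatter), so an aromatic ring at this position brought no measurable gain, although that floor rests on a limit. The step from compound 1 to compound 3 cannot be read, since both values are limits. Going by these compounds alone, only one of the three compounds has an actual number, and the others share one reading: the limit of > 100000 nM in this assay, at which 2 of the 3 values shown sit.

On these data alone, whether an amine, a carboxylic acid or a longer chain on this carbonyl carbon would give a number stays open. So does how far compound 3 actually lies from compound 2.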